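Swapping Iodine for Chlorine on a Cyclic Nucleotide

The source may report more compounds than this note shows. Statements on the series, on what has been measured and on what is new or still open speak of the compounds shown alone.

Two nucleotide analogues have been tested in a functional assay on L1210 cells (Mus musculus); on this read-out lower numbers stand for stronger inhibition and higher numbers for weaker inhibition. Compound 1 `O=c1[nH]c(=O)n([C@@H]2O[C@H](COP(=O)(O)O)[C@@H](O)[C@H]2O)cc1Br` gives 376 ug/mL. Compound 2 `O=c1[nH]c(=O)n([C@@H]2O[C@@H]3COP(=O)(O)O[C@H]3[C@H]2O)cc1I` gives 344 ug/mL, the smaller of the two numbers, though the gap to compound 1 lies within the usual scatter, so neither stands apart. Compound 3 `O=c1[nH]c(=O)n([C@@H]2O[C@@H]3COP(=O)(O)O[C@H]3[C@H]2O)cc1Cl` carries the change (chloro in place of iodo on an aromatic carbon). Within the data shown here, no measured pair shows what such a halogen swap does here, so only a modest shift is anticipated. The expected step of a 1.2-fold higher number from compound 2 to compound 3 (0.07 log units; within the scatter) is small, pointing to a slightly higher number if anything. Compound 3 is estimated to give about 400 ug/mL, within a range from 200 ug/mL to 800 ug/mL.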

Compound 3, concentration for 50% inhibition: > 1000 ug/mL
Compound 3: no number, only a limit; the forecaster's own chance of this, stated with the estimate: 10%; at least 2.5-fold (0.39 log units) between middle value and limit.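

Among these compounds, compound 2 and compound 3 are the only pair here that differ in one place, so they give the first direct reading of a change at this position. Chloro in place of iodo on an aromatic carbon gives an at least 2.9-fold higher number from compound 2 to compound 3 (0.46 log units; beyond the scatter), so the choice between these two halogens does register in this assay. For compound 3 the result is a limit and not a number, so the full size of the step stays unknown: the limit of > 1000 ug/mL in this assay, at which 1 of the 3 values shown sits.

The compounds shown leave open how an amine or a methyl group at this position would read. They also leave open whether the same swap would have a similar effect on the core of compound 1.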